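Para substituent on the aryl ring of the shared core

The source may hold more compounds than are shown below. What is called first, only, known or untested is meant among the compounds shown, and "the series" means these compounds.

Measured so far:
compound 1 `Cc1[nH]c(=O)n(C)c1-c1ccccc1` — > 100000 nM
compound 2 `CCCCCc1ccc(-c2c(C)[nH]c(=O)n2C)cc1` — 5900 nM

In a functional assay on brain (Rattus norvegicus, strain Wistar) for inhibition (a lower number here means a stronger inhibitor, a higher number a weaker inhibitor), compound 1 gives > 100000 nM; this is a limit of the assay and not a number, so compound 1 stands only at a limit (the limit of > 100000 nM in this assay, at which 1 of the 2 values shown sits). In this assay compound 2 gives 5900 nM. The step between them is an at least 16-fold lower number from compound 1 to compound 2 (1.22 log units; beyond the scatter).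

Compound 3 `Cc1[nH]c(=O)n(C)c1-c1ccc(C2CCCCC2)cc1` differs from compound 1 by cyclohexyl in place of hydrogen on an aromatic carbon. For the measured compounds named here, the only measured step that bears on this change is an at least 16-fold lower number from compound 1 to compound 2 (1.22 log units; beyond the scatter), a large one, so a lowering of similar size is expected, an at least 16-fold lower number from compound 1 to compound 3 (1.22 log units; beyond the scatter). Compound 3 is therefore estimated at 6000 nM, with a range from 2000 nM to 25000 nM.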

Compound 3, half-maximal inhibitory concentration: 10000 nM
The estimate for compound 3 lay 1.7-fold (0.22 log units) below the measured number, within the range that was stated.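

Cyclohexyl on this aromatic carbon also gives a clear drop, with an at least 10-fold lower number from compound 1 to compound 3 (1.00 log units; beyond the scatter), so the lowering seen with pentyl is not confined to an open chain. Pentyl and cyclohexyl cannot be told apart here, with a 1.7-fold higher number from compound 2 to compound 3 (0.23 log units; within the scatter). The size of the drop from compound 1 remains only a bound, as its value is a limit of the assay and not a number: the limit of > 100000 nM in this assay, at which 1 of the 3 values shown sits.

Open, on these data alone, is whether a longer chain at this position lowers the number further. Also open, as far as these compounds go, is how an amine or a carboxylic acid there would compare with pentyl and cyclohexyl.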